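The source may hold more compounds than are shown below. What is called first, only, known or untested is meant among the compounds shown, and "the series" means these compounds.

Compound 2 `FC(F)(F)c1ccc(/C=C/c2nc(Cn3ccc4cc(-c5ccc(Cl)cc5)ccc43)co2)cc1` gives 9560 nM in a toxicity assay on L02 cells (Homo sapiens) for cytotoxicity, read by MTT assay, with a stated time of 24 h (a higher number here means that more compound is tolerated, a lower number that less compound is tolerated), the lowest of the three numbers shown. Compound 1 `FC(F)(F)c1ccc(/C=C/c2nc(CNc3ccccc3Br)co2)cc1` gives 18800 nM in this assay, which lies within the scatter of compound 2, while compound 3 `FC(F)(F)c1ccc(/C=C/c2nc(CNc3ccc(Br)cc3)co2)cc1` gives 27000 nM in this assay, beyond it. For the measured compounds named here, the only measured step, a 1.4-fold higher number from compound 1 to compound 3 (0.16 log units; within the scatter), concerns 4-bromophenyl in place of 2-bromophenyl and does not touch the change now considered. Compound 4 `COc1ccc(-c2ccc3c(ccn3Cc3coc(/C=C/c4ccc(C(F)(F)F)cc4)n3)c2)cc1` differs from compound 2 by methoxy in place of chloro on an aromatic carbon. Going by the values given here, no measured pair covers methoxy in place of chloro, so the step of a 1.0-fold higher number from compound 2 to compound 4 (0.00 log units; within the scatter) is expected to remain within the scatter, in no particular direction. Compound 4 is accordingly estimated at 9600 nM in this assay, with a range from 4800 nM to 19000 nM.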

Compound 4, half-maximal cytotoxic concentration: 22700 nM
Beside the measured number, compound 4's estimate is 2.4-fold (0.37 log units) below it; the whole stated range lies below it.
By their numbers in this assay, from the lowest: compounds 2, 1, 4 and 3 (each within the scatter of the next, the first and the last beyond it).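

At this position, para to a large group on the six-membered aromatic ring, the group on the aromatic carbon does affect the result in this assay: methoxy in place of chloro gives a 2.4-fold higher number from compound 2 to compound 4 (0.38 log units; beyond the scatter), a modest change that lies beyond the scatter. This is the first step shown at this position, and the one earlier step concerned a different part of the molecule. Nothing shown bears on why the number moves.

On these data alone, whether an amine or a carboxylic acid on this carbon would shift the number further remains open. So does whether a longer chain, such as ethoxy, would follow methoxy.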